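The source may hold more compounds than are shown below. What is called first, only, known or untested is meant among the compounds shown, and "the series" means these compounds.

Of the compounds shown here, two have been measured in an assay on isolated protein for antagonist activity at Bile acid receptor (Homo sapiens), read by TR-FRET, with a stated time of 20 min; on this read-out higher numbers stand for weaker inhibition and lower numbers for stronger inhibition. Compound 1 `O=C(Nc1ccc(F)c(S(=O)(=O)N2CCOCC2)c1)c1cnn(-c2ccccc2)c1` gives 8300 nM in this assay, while compound 2 `Cc1ccc(-c2nn(-c3cccc(Cl)c3)cc2C(=O)Nc2ccc(C)c(S(=O)(=O)N3CCOCC3)c2)cc1` gives 10.4 nM. Compound 2 therefore holds the lowest of the two numbers, and the gap to compound 1 lies well beyond the usual scatter of such measurements. The two structures differ in several places at once, so no single change can be tied to this gap.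

Compound 3 `Cc1ccc(-c2nn(C(C)C)cc2C(=O)Nc2ccc(C)c(S(=O)(=O)N3CCOCC3)c2)cc1` is drawn from compound 2 by a single change: isopropyl in place of 3-chlorophenyl on an aromatic nitrogen. For the measured compounds named here, no measured pair shows this exchange, so its effect can only be estimated. Going by the values given here, since the only highly potent compound, compound 2, carries an aromatic group at that position and nothing else is known, a weakening step from compound 2 to compound 3 of a 14-fold higher number from compound 2 to compound 3 (1.16 log units; beyond the scatter) in this assay is expected. Compound 3 is estimated at 150 nM, within a range from 25 nM to 1000 nM.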

Compound 3, half-maximal inhibitory concentration: 49.1 nM
Compound 3: the middle estimate sits 3.1-fold (0.49 log units) above what was measured; the range from low to high includes it.
By their numbers in this assay, from the lowest: compound 2; then compound 3; then compound 1.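

In this assay, isopropyl in place of 3-chlorophenyl on the aromatic nitrogen gives a 4.7-fold higher number from compound 2 to compound 3 (0.67 log units; beyond the scatter), a modest step that lies beyond the scatter. An aromatic ring at this position is therefore not required for a number well into the nanomolar range, since compound 3, with a group that has no ring and fewer heavy atoms, still gives 49.1 nM. Nothing available here accounts for the size of the step.

The exchange removes the ring and the chlorine together, so the compounds shown leave open how much of the step belongs to each; an unsubstituted phenyl on this nitrogen of the shared core would separate the two. Going by these compounds, it also remains open how a cyclohexyl, a methyl or a longer chain at this position would compare with isopropyl.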